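Compound 3 to compound 4: fluoro in place of methoxy

A few compounds are considered here, and "the series" means these few. Any claim that something is new, unique, unknown or untested is made for them only; others in the source may bear on it.

In a functional assay on M14 cells (Homo sapiens) for cytotoxicity (a higher number here means a weaker inhibitor of growth, a lower number a stronger inhibitor of growth), compound 3 (`COc1ccc(C2=C(c3ccc(SC)cc3)CC3CCCN3C2=O)cc1`) gives 4000 nM. Compound 2 (`COc1ccc(C2=C(c3ccc(SC)cc3)CC3CCCN3C2=O)cc1OC`) gives 5000 nM, within the scatter of compound 3. Compound 1 (`COc1ccc(C2=C(c3cc(OC)c(OC)c(OC)c3)CC3CCCN3C2=O)cc1O`) reports > 100000 nM, which is a limit of the assay and not a number. For the measured compounds named here, compound 3 therefore stands level with compound 2, the only other compound with a numeric value.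

Compound 4 (`CSc1ccc(C2=C(c3ccc(F)cc3)C(=O)N3CCCC3C2)cc1`) carries fluoro in place of methoxy on an aromatic carbon, para to a large group: fluoro in place of methoxy on an aromatic carbon. In the wider cut, this reads 4-methoxyphenyl to 4-fluorophenyl.

Going by the values given here, one measured step bears on this change, and only indirectly. Hydrogen in place of methoxy on the same aromatic ring gave a 1.3-fold lower number from compound 2 to compound 3 (0.10 log units; within the scatter). That step removed a different methoxy, so the methoxy now leaving has not been varied in any measured pair. The data give no firm direction, and a step beyond the scatter is not expected, although the uncertainty is wide. The expected change is a 1.5-fold higher number from compound 3 to compound 4 (0.18 log units; within the scatter). For compound 4 the estimated value is 6000 nM, with an expected range of 2000 nM to 25000 nM.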

Compound 4, concentration for 50% growth inhibition: 600 nM
Estimate against measurement, compound 4: 10-fold (1.00 log units) above; the measured number lies below the stated range.
By their numbers in this assay, from the lowest: compound 4; then compounds 3 and 2 (each within the scatter of the next). At a limit, above all of these: compound 1.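

Para to a large group, the 4-methoxyphenyl to 4-fluorophenyl change gives the first step in this series that clears the scatter in this assay: a 6.7-fold lower number from compound 3 to compound 4 (0.82 log units; beyond the scatter). For the compounds shown here, the only earlier comparison on this ring removed the other methoxy, a 1.3-fold lower number from compound 2 to compound 3 (0.10 log units; within the scatter), and so gave no sign that the ring could respond to substitution; this position now proves sensitive, with the methoxy here and the fluoro differing measurably in the growth read-out. Nothing measured for these compounds accounts for the step, so the change is recorded only as an observation.

Going by these compounds alone, the series holds no compound with plain hydrogen at this position. The data cannot separate losing the methoxy from gaining the fluoro. On these data alone, how far the trend extends to other replacements here, such as chloro, trifluoromethyl, nitrile or an amine, also remains open, as does whether the fluoro would keep its effect with the methylthio group on the other aryl ring replaced.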